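The compounds below may be only part of what the source reports. "The series", "measured", "known", "first", "only" and "open" are said of these compounds alone.

Compound 1, `COc1cccc(OC)c1OCCNCCOc1ccccc1OCc1ccccc1`, gives 8.3 in a functional assay on spleen for antagonist activity at Alpha-1B adrenergic receptor (Rattus norvegicus); a higher number here means a more potent compound, by a factor of ten per unit of this negative logarithm, a lower number a less potent compound.
Compound 2, `COc1cccc(OC)c1OCCNCCOc1ccccc1OCc1ccc(C)cc1`, gives 8.43 in this assay.
Compound 3, `COc1ccccc1COc1ccccc1OCCNCCOc1c(OC)cccc1OC`, gives 8.13 in this assay.

Compound 3 has the lowest of the three numbers, yet both gaps, a number 0.17 log units lower from compound 1 to compound 3 (within the scatter) and a number 0.30 log units lower from compound 2 to compound 3 (within the scatter), stay within the scatter, so the three compounds cannot be told apart here. Compound 4, `CCOc1ccc(COc2ccccc2OCCNCCOc2c(OC)cccc2OC)cc1`, differs from compound 3 by 4-ethoxyphenyl in place of 2-methoxyphenyl on a saturated chain carbon bound to an oxygen on an aromatic ring. The 4-ethoxyphenyl resembles the 4-methylphenyl of compound 2, so the step of a number 0.30 log units lower from compound 2 to compound 3 (within the scatter) bears most on it, and a number 0.13 log units higher from compound 1 to compound 2 (within the scatter) shows that such a group changed little. On these data alone, an ethoxy group is untested, so in this assay a step of a number 0.22 log units higher from compound 3 to compound 4 (within the scatter) is expected, no larger than the scatter. Compound 4 is therefore estimated at 8.35, ranging from 7.9 to 8.8.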

Compound 4, negative logarithm of the antagonist equilibrium constant: 8.23
Beside the measured number, compound 4's estimate is 0.12 log units above it; the range from low to high includes it.
By their numbers in this assay, from the lowest: compounds 3, 4, 1 and 2 (each within the scatter of the next).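

In this assay, within the data shown here, the ethoxy group on the aromatic ring of this side group gives no step that stands out: a number 0.10 log units higher from compound 3 to compound 4 (within the scatter) and a number 0.20 log units lower from compound 2 to compound 4 (within the scatter) and also a number 0.07 log units lower from compound 1 to compound 4 (within the scatter) all stay small. Compounds 1, 2, 3 and 4 therefore cannot be told apart, whether this ring carries only hydrogen or a methyl, methoxy or ethoxy group, and none of the four goes against this. Nothing here explains why these changes read alike. On these data alone, whether an amine, a carboxylic acid or a longer butoxy chain on this ring would move the number remains open.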